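Group swaps on the amide-type nitrogen: compound 3 to compound 4

A few compounds are considered here, and "the series" means these few. Any claim that something is new, unique, unknown or untested is made for them only; others in the source may bear on it.

compound 1 `Cc1ccc(NC(=O)[C@@H]2CCCN2S(=O)(=O)c2cccc3cccnc23)cc1` gives 31700 nM
compound 2 `CCc1ccccc1NC(=O)[C@@H]1CCCN1S(=O)(=O)c1cccc2cccnc12` gives > 50000 nM as a limit
compound 3 `Cc1cc(C)cc(NC(=O)[C@@H]2CCCN2S(=O)(=O)c2cccc3cccnc23)c1` gives 31300 nM

Among the compounds with values here, in an ADME assay on HEp-2 cells (Homo sapiens) for cytotoxicity (on this read-out lower numbers stand for higher toxicity in this test and higher numbers for lower toxicity in this test), compound 3 gives 31300 nM and sits level with compound 1 (31700 nM), the only other number. Compound 2 stands at a limit and not at a number (the limit of > 50000 nM in this assay, at which 1 of the 3 values shown sits). The two steps that touch it (an at least 1.5-fold higher number from compound 1 to compound 2 (0.19 log units; that floor lies within the scatter) and an at least 1.5-fold lower number from compound 2 to compound 3 (0.20 log units; that floor lies within the scatter)) are floors only.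

Compound 4 `O=C(Nc1ccc(Cl)cc1Cl)[C@@H]1CCCN1S(=O)(=O)c1cccc2cccnc12` carries 2,4-dichlorophenyl in place of 3,5-dimethylphenyl on an amide-type nitrogen. Within the data shown here, no measured compound carries 2,4-dichlorophenyl, so the only guide is the earlier swaps at that nitrogen. Among the measured compounds shown here, the one step between two true numbers (a 1.0-fold lower number from compound 1 to compound 3 (0.01 log units; within the scatter)) stayed within the scatter, and the floors involving compound 2 go no further.

No move beyond the scatter is expected in this assay, in either direction. The expected step is a 1.0-fold lower number from compound 3 to compound 4 (0.02 log units; within the scatter) and it is estimated to stay that small. For compound 4 the estimated value is 30000 nM with an expected range from 13000 nM to 50000 nM and some chance of a limit instead of a number.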

Compound 4, half-maximal cytotoxic concentration: > 50000 nM
Compound 4 gave a limit, no number (the forecaster's own chance of this, stated with the estimate: 25%); at least 1.6-fold (0.22 log units) between middle value and limit.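

In this assay, 2,4-dichlorophenyl is the first group with chlorine on the amide-type nitrogen, and compound 4 joins compound 2 at a limit rather than giving a number: the limit of > 50000 nM in this assay, at which 2 of the 4 values shown sit.

The series now shows an at least 1.5-fold higher number from compound 3 to compound 4 (0.20 log units; that floor lies within the scatter) and an at least 1.5-fold higher number from compound 1 to compound 4 (0.19 log units; that floor lies within the scatter), so the swap is not shown to move the read-out beyond the scatter, though the floors do not confine it to the scatter either, and the step between the two compounds at the limit cannot be read. Among these four compounds, the two groups named with a substituent at position 2, in compound 2 and compound 4, are the two that end at the limit, while compound 1 and compound 3 give numbers, but four compounds are too few to make this more than an observation, and compound 4 also carries a substituent at position 4, as compound 1 does.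

From the compounds shown here alone, how far compound 2 and compound 4 actually lie from the limit stays open. A 2-chlorophenyl or a 4-chlorophenyl group on the same nitrogen would show which chlorine goes with the limit, and a carboxylic acid on the phenyl ring would test a very different kind of group at this position.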